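A Methyl Swap at the Assay Limit

The source may hold more compounds than are shown below. What is called first, only, known or untested is meant among the compounds shown, and "the series" means these compounds.

In a functional assay on A549 cells (Homo sapiens) for cytotoxicity, read by MTT assay, with a stated time of 48 h (on this read-out higher numbers stand for weaker inhibition and lower numbers for stronger inhibition), compound 1 (`COC(=O)c1ccc(-n2cc(CCCOS(=O)(=O)c3ccc(C)cc3)nn2)cc1`) gives > 100000 nM, which is a limit and not a number. Compound 2 (`Cc1ccc(S(=O)(=O)OCCCc2cn(-c3cccc(C#N)c3)nn2)cc1`) gives > 100000 nM, also a limit. Compound 3 (`Cc1ccc(S(=O)(=O)OCCCc2cn(-c3cccc(F)c3)nn2)cc1`) gives > 100000 nM, again a limit. Compound 1 therefore stands with the other two, as the limit of > 100000 nM in this assay, at which 3 of the 3 values shown sit, shows. Among the measured compounds shown here, the only measured step, a step that the two limits leave unreadable from compound 2 to compound 3, offers no size to carry over. Compound 4 (`Cc1ccc(-n2cc(CCCOS(=O)(=O)c3ccc(C)cc3)nn2)cc1`) has methyl in place of methoxycarbonyl on an aromatic carbon. With no readable step to suggest a gain, no clear change is expected. The estimated step is a step that the limit leaves unreadable from compound 1 to compound 4. For compound 4 the estimate is 120000 nM, with an expected range from 50000 nM to 300000 nM.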

Compound 4, half-maximal inhibitory concentration: 79900 nM
Beside the measured number, compound 4's estimate is 1.5-fold (0.18 log units) above it; low and high end bracket the measured number.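

Among the compounds shown here, compound 4 is the first compound in this assay to give a number and not a limit, and it does so with only methyl on the aromatic ring, para to a large group. Methyl in place of methoxycarbonyl gives an at least 1.2-fold lower number from compound 1 to compound 4 (0.09 log units; that floor lies within the scatter), while the two swaps of the whole aromatic group give an at least 1.2-fold lower number from compound 3 to compound 4 (0.09 log units; that floor lies within the scatter) and an at least 1.2-fold lower number from compound 2 to compound 4 (0.09 log units; that floor lies within the scatter). These are floors only, so the real size of each step stays unread, and the series still sits mostly at one edge of the assay: the limit of > 100000 nM in this assay, at which 3 of the 4 values shown sit.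

Going by these compounds, whether an amine or a carboxylic acid in the same place would also give a number stays open.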